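Sulfonamide-to-amide switch on the pyrimidine-linked chain

The source may report more compounds than this note shows. Statements on the series, on what has been measured and on what is new or still open speak of the compounds shown alone.

Measured so far:
compound 1 `O=S(=O)(NCCCNc1nccc(-c2c(-c3cccc(F)c3)nc3sccn23)n1)c1cccc(F)c1` — 8550 nM
compound 2 `O=S(=O)(NCCNc1nccc(-c2c(-c3cccc(F)c3)nc3sccn23)n1)c1ccc(Cl)cc1` — 18600 nM

Within the data shown here, in a functional assay on SK-MEL-28 cells (Homo sapiens) for cytotoxicity, read by MTT assay (a lower number here means a stronger inhibitor, a higher number a weaker inhibitor), compound 2 gives the highest of the two numbers; the one step to it, a 2.2-fold higher number from compound 1 to compound 2 (0.34 log units; beyond the scatter), is modest but beyond the scatter. Compound 3 `O=C(NCCCNc1nccc(-c2c(-c3cccc(F)c3)nc3sccn23)n1)c1ccc(Cl)cc1` differs from compound 2 by (((4-chlorophenyl)carbonyl)amino)methyl in place of ((4-chlorophenyl)sulfonyl)amino on a saturated chain carbon, two bonds along the chain from a nitrogen on an aromatic ring. That step changes both the linking group and the chain length; only the chain part echoes the measured step, which went the other way. A small step back toward compound 1 is therefore expected, a 1.9-fold lower number from compound 2 to compound 3 (0.27 log units; within the scatter). Compound 3 is estimated at 10000 nM, range 4000 nM to 25000 nM.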

Compound 3, half-maximal inhibitory concentration: > 20000 nM
Compound 3: only a limit was reported; the forecaster's own chance of this, stated with the estimate: 10%; middle value at least 2.0-fold (0.30 log units) from the limit.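

In this assay, compound 3 is reported only as a limit: the limit of > 20000 nM in this assay, at which 1 of the 3 values shown sits.

On an amine nitrogen, (4-chlorophenyl)carbonyl in place of (3-fluorophenyl)sulfonyl gives an at least 2.3-fold higher number from compound 1 to compound 3 (0.36 log units; beyond the scatter), a step that is at least modest, so on this chain the carbonyl link brings no gain over the sulfonyl link. On a saturated chain carbon, two bonds along the chain from a nitrogen on an aromatic ring, (((4-chlorophenyl)carbonyl)amino)methyl in place of ((4-chlorophenyl)sulfonyl)amino gives an at least 1.0-fold higher number from compound 2 to compound 3 (0.03 log units; that floor lies within the scatter), and that floor lies within the scatter.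

The aryl group changes along with the link, so the shown compounds do not separate the two contributions. Also open, as far as these compounds go, are a (3-fluorophenyl)carbonyl group on this chain and a longer chain with either link.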